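Compound 3 to compound 4: cyclopropyl for oxan-4-yl

The source may report more compounds than this note shows. Statements on the series, on what has been measured and on what is new or still open speak of the compounds shown alone.

In a functional assay on HCC827 cells (Homo sapiens) for antiproliferative activity, read by MTT assay, with a stated time of 72 h (a higher number here means a weaker inhibitor, a lower number a stronger inhibitor), compound 1 `CN1CCN(c2ccc(Nc3ncc4nc(SCc5ccccc5)n(C5CCOCC5)c4n3)cc2)CC1` gives 107 nM, the strongest of the three measured compounds. Compound 2 `CN1CCN(c2ccc(Nc3ncc4nc([S+]([O-])Cc5ccccc5)n(C5CCOCC5)c4n3)cc2)CC1` gives 433 nM, and compound 3 `CN1CCN(c2ccc(Nc3ncc4nc(SCc5cccnc5)n(C5CCOCC5)c4n3)cc2)CC1` gives 500 nM. Compound 3 has the highest number, but it stands level with compound 2, since a 1.2-fold higher number from compound 2 to compound 3 (0.06 log units; within the scatter) lies within the scatter. Only compound 1 stands clearly apart, with a 4.7-fold higher number from compound 1 to compound 3 (0.67 log units; beyond the scatter).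

Compound 4 `CN1CCN(c2ccc(Nc3ncc4nc(SCc5cccnc5)n(C5CC5)c4n3)cc2)CC1` differs from compound 3 at one place: cyclopropyl in place of oxan-4-yl on an aromatic nitrogen. For the measured compounds named here, no measured step touches this position, as all three measured compounds carry oxan-4-yl. The changes elsewhere, a 4.0-fold higher number from compound 1 to compound 2 (0.61 log units; beyond the scatter) and the pyridin-3-yl step from compound 1 above, offer only a rough measure of how far one change can move the number in this small set. Going by these compounds, they give no direction for the new change, so a move of similar size either way remains open. The estimated step is no change at the digits printed from compound 3 to compound 4 (within the scatter), with no direction expected. Compound 4 is estimated at 500 nM, with an expected range of 130 nM to 1900 nM.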

Compound 4, half-maximal inhibitory concentration: 8830 nM
Compound 4: the middle estimate sits 18-fold (1.25 log units) below what was measured, outside the stated range (above it).
By their numbers in this assay, from the lowest: compound 1; then compounds 2 and 3 (each within the scatter of the next); then compound 4.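

In this assay, the group on the aromatic nitrogen turns out to matter a great deal: an 18-fold higher number from compound 3 to compound 4 (1.25 log units; beyond the scatter) is a larger move than either earlier change elsewhere in the series, a 4.0-fold higher number from compound 1 to compound 2 (0.61 log units; beyond the scatter) and a 4.7-fold higher number from compound 1 to compound 3 (0.67 log units; beyond the scatter). With the ((pyridin-3-yl)methyl)sulfanyl group in place, oxan-4-yl is clearly preferred to cyclopropyl, so this position does not tolerate every small ring equally. Nothing at hand explains the loss.

For the compounds shown here, the single swap changes ring size and removes the ring oxygen together, so cyclohexyl, which has a six-membered ring with no oxygen, and oxetan-3-yl, a small ring that keeps an oxygen, would be needed to separate the two. Going by these compounds, whether cyclopropyl costs as much alongside the benzylsulfanyl group of compound 1 also remains open.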